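Shortening the Sulfonamide Side Chain: An Expected Result

The compounds below may be only part of what the source reports. "The series", "measured", "known", "first", "only" and "open" are said of these compounds alone.

Three compounds share one core and differ only in the group on the sulfonamide nitrogen. Compound 1 `CCCNS(=O)(=O)c1ccc(Nc2ncc3c(n2)N(C2CCCC2)[C@H](CC)C(=O)N3C)cc1` carries a propyl chain; in a functional assay on MCF7 cells (Homo sapiens) for antiproliferative activity, read by CCK-8 assay, with a stated time of 72 h (a higher number here means a weaker inhibitor of growth, a lower number a stronger inhibitor of growth), compound 1 gives 344 nM. Compound 2 `CC[C@@H]1C(=O)N(C)c2cnc(Nc3ccc(S(=O)(=O)NCCO)cc3)nc2N1C1CCCC1` carries a 2-hydroxyethyl chain, and in this assay compound 2 gives 344 nM. Compound 3 `CC[C@@H]1C(=O)N(C)c2cnc(Nc3ccc(S(=O)(=O)NCCCO)cc3)nc2N1C1CCCC1` carries a 3-hydroxypropyl chain, and in this assay compound 3 gives 363 nM. That is the highest of the three numbers, a distinction without weight here, as every gap between these compounds lies within the scatter.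

The steps bear this out: no change at the digits printed from compound 1 to compound 2 (within the scatter); a 1.1-fold higher number from compound 1 to compound 3 (0.02 log units; within the scatter); a 1.1-fold higher number from compound 2 to compound 3 (0.02 log units; within the scatter). Each alters the chain on the sulfonamide nitrogen, and none moves the number beyond the scatter.

Compound 4 `CC[C@@H]1C(=O)N(C)c2cnc(Nc3ccc(S(=O)(=O)NC)cc3)nc2N1C1CCCC1` cuts that chain back to a single methyl: hydrogen in place of 2-hydroxyethyl on a saturated chain carbon bound to a sulfonamide nitrogen. Because no change at the digits printed from compound 1 to compound 2 (within the scatter), a 1.1-fold higher number from compound 1 to compound 3 (0.02 log units; within the scatter) and a 1.1-fold higher number from compound 2 to compound 3 (0.02 log units; within the scatter) all lie within the scatter, the step expected is a 1.0-fold lower number from compound 3 to compound 4 (0.02 log units; within the scatter). Compound 4 is therefore estimated at 350 nM, with a range from 180 nM to 700 nM.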

Compound 4, concentration for 50% growth inhibition: 151 nM
Estimate against measurement, compound 4: 2.3-fold (0.37 log units) above, outside the stated range (below it).
By their numbers in this assay, from the lowest: compound 4; then compounds 1, 2 and 3 (each within the scatter of the next).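

Among the compounds shown here, this position is not as indifferent as the first three compounds suggested: propyl, 2-hydroxyethyl and 3-hydroxypropyl chains could not be told apart, but the single methyl of compound 4 does separate from them. The steps are a 2.4-fold lower number from compound 3 to compound 4 (0.38 log units; beyond the scatter) and a 2.3-fold lower number from compound 2 to compound 4 (0.36 log units; beyond the scatter) and a 2.3-fold lower number from compound 1 to compound 4 (0.36 log units; beyond the scatter), each a modest gain in growth inhibition, and they show that cutting the chain back can matter even where swapping one longer chain for another did not. Nothing available explains this difference.

The compounds shown leave open whether an ethyl chain on the sulfonamide nitrogen would group with the methyl of compound 4 or with the longer chains, and whether a bare sulfonamide with hydrogen there would give a lower number still. They also leave open whether a chain ending in an amine or a carboxylic acid would match the hydroxy chains.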